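A second fluorine on the aryl ring of compound 3

The source may hold more compounds than are shown below. What is called first, only, known or untested is meant among the compounds shown, and "the series" means these compounds.

Compound 1, `Cc1cc(=O)n(-c2ccccc2OC(F)(F)F)nc1C(=O)Nc1ccc(Oc2ncnc3sccc23)cc1`: 11000 nM
Compound 2, `Cc1ccc(-n2nc(C(=O)Nc3ccc(Oc4ncnc5sccc45)cc3)c(C)cc2=O)cc1`: > 40000 nM (a limit of the assay, not a number)
Compound 3, `Cc1cc(=O)n(-c2ccc(F)cc2)nc1C(=O)Nc1ccc(Oc2ncnc3sccc23)cc1`: 21000 nM

All three share one core and differ only in the aryl group on an aromatic nitrogen. In a functional assay on MCF7 cells (Homo sapiens) for cytotoxicity, read by MTT assay, with a stated time of 72 h (on this read-out lower numbers stand for stronger inhibition and higher numbers for weaker inhibition), compound 3 gives 21000 nM, and compound 1 gives 11000 nM; these two lie within the scatter of each other, the step being a 1.9-fold higher number from compound 1 to compound 3 (0.28 log units; within the scatter). For compound 2 the this assay reports only a limit, > 40000 nM; it is the limit of > 40000 nM in this assay, at which 1 of the 3 values shown sits. From compound 1 to compound 2 the step is an at least 3.6-fold higher number from compound 1 to compound 2 (0.56 log units; beyond the scatter), and from compound 2 to compound 3 it is an at least 1.9-fold lower number from compound 2 to compound 3 (0.27 log units; that floor lies within the scatter).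

Compound 4, `Cc1cc(=O)n(-c2ccc(F)c(F)c2)nc1C(=O)Nc1ccc(Oc2ncnc3sccc23)cc1`, keeps everything of compound 3 except one change: fluoro in place of hydrogen on an aromatic carbon. Within the data shown here, no measured step adds a fluoro to a ring already carrying one; the closest guides are the aryl swaps, a 1.9-fold higher number from compound 1 to compound 3 (0.28 log units; within the scatter) and an at least 1.9-fold lower number from compound 2 to compound 3 (0.27 log units; that floor lies within the scatter), one within the scatter and one whose floor lies within it. From compound 3 to compound 4 the expected step is therefore a 1.1-fold lower number from compound 3 to compound 4 (0.02 log units; within the scatter), none beyond the scatter. Compound 4 is estimated in this assay at 20000 nM, with a range from 8000 nM to 50000 nM.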

Compound 4, half-maximal inhibitory concentration: 16100 nM
For compound 4 the middle estimate is 1.2-fold (0.09 log units) above the measured one; low and high end bracket the measured number.
By their numbers in this assay, from the lowest: compounds 1, 4 and 3 (each within the scatter of the next). At a limit, above all of these: compound 2.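

Fluoro in place of hydrogen on this aromatic carbon, ortho to a fluoro group, gives a 1.3-fold lower number from compound 3 to compound 4 (0.12 log units; within the scatter), so in this assay this change has no effect that can be told apart from the scatter. The 3,4-difluorophenyl group is also not separated from the 2-(trifluoromethoxy)phenyl group, with a 1.5-fold higher number from compound 1 to compound 4 (0.17 log units; within the scatter), but it does separate from the 4-methylphenyl group, with an at least 2.4-fold lower number from compound 2 to compound 4 (0.39 log units; beyond the scatter), even though that step is only a floor. Compound 2 gives no number to set against the others, only a limit of the assay: the limit of > 40000 nM in this assay, at which 1 of the 4 values shown sits.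

Going by these compounds, it remains open what a chloro, a methoxy or an amine on this same ring carbon would do. On these data alone, it is also open whether any group here could take the read-out beyond the scatter from compound 3.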